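Removing the Amine Methyl from Compound 2

A few compounds are considered here, and "the series" means these few. Any claim that something is new, unique, unknown or untested is made for them only; others in the source may bear on it.

Among the three compounds measured in an assay on a protein complex for displacement of a labelled ligand from Neuronal acetylcholine receptor; alpha4/beta4 (Rattus norvegicus), read by scintillation counting (a higher number here means a weaker inhibitor, a lower number a stronger inhibitor), compound 2 `CN1CCCN(c2cncc(-c3cc(CCO)no3)c2)CC1` stands highest, with 4940 nM. Compound 1 `COCC[C@H]1C[C@@H]1c1cncc(N2CCCNCC2)c1` gives 151 nM, and compound 3 `COCC[C@@H]1C[C@H]1c1cncc(N2CCCNCC2)c1` gives 168 nM. The step of a 1.1-fold higher number from compound 1 to compound 3 (0.05 log units; within the scatter) is accounted for by the fact that compounds 1 and 3 differ only in the configuration as drawn, and the two values are read as a single level. Compound 2 thus sits well above compound 1 and compound 3 in this assay, although it differs from both in more than one place, so the gap cannot be assigned to any single change.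

Compound 4 `OCCc1cc(-c2cncc(N3CCCNCC3)c2)on1` has not yet been measured. It differs from compound 2 by hydrogen in place of methyl on an amine nitrogen in a ring. For the measured compounds named here, no measured step concerns that amine: the only measured step, a 1.1-fold higher number from compound 1 to compound 3 (0.05 log units; within the scatter), changes configuration alone and leaves the amine untouched. Compound 1 and compound 3, which carry the unmethylated amine, show lower numbers than compound 2, but their other substituent differs as well, so their values give only a hint of direction, not of size. Compound 4 is therefore expected to give 1200 nM, with a range from 300 nM to 5000 nM. This corresponds to an expected step of a 4.1-fold lower number from compound 2 to compound 4 (0.61 log units; beyond the scatter) in this assay.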

Compound 4, inhibition constant: 67.6 nM
Compound 4: the middle estimate sits 18-fold (1.25 log units) above what was measured; measured number below the stated range.
By their numbers in this assay, from the lowest: compound 4; then compounds 1 and 3 (each within the scatter of the next); then compound 2.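

In this assay, for the compounds shown here, the step of a 73-fold lower number from compound 2 to compound 4 (1.86 log units; beyond the scatter) is the first measured change at the amine nitrogen of the seven-membered ring, and it shows that the result is highly sensitive to what this nitrogen carries. With the rest of the structure unchanged, exchanging a single methyl, one carbon with no ring, for hydrogen is enough to produce a large step, and in this pair the form with hydrogen on the nitrogen is clearly the stronger inhibitor. Going by these compounds alone, the only earlier step changed configuration alone and left this nitrogen untouched, and nothing given here accounts for the size of the new step.

On these data alone, whether the effect is specific to methyl remains open, since an ethyl group, a longer chain or an acetyl group on the same nitrogen would show whether larger groups there behave in the same way. As far as these compounds go, the reading also rests on a single pair, so it is open whether removing a methyl from this nitrogen would give a step of similar size on the core of compound 1.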